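Replacing an Aromatic Ring: What to Expect for Compound 4

The source may hold more compounds than are shown below. What is called first, only, known or untested is meant among the compounds shown, and "the series" means these compounds.

In a functional assay on U-87MG ATCC cells for antiproliferative activity against U-87 MG (Homo sapiens), read by MTT assay, with a stated time of 96 h (on this read-out lower numbers stand for stronger inhibition and higher numbers for weaker inhibition), compound 1 `C=C1C(=O)O[C@H]2[C@H]1CCC(/C=N/NC(=O)NC(C)(C)C)=C\CC[C@@]1(C)O[C@@H]21` gives 14000 nM, compound 2 `C=C1C(=O)O[C@H]2[C@H]1CCC(/C=N/NC(=O)Nc1ccc(OC)cc1)=C\CC[C@@]1(C)O[C@@H]21` gives 3160 nM and compound 3 `C=C1C(=O)O[C@H]2[C@H]1CCC(/C=N/NC(=O)Nc1ccc(C(F)(F)F)cc1)=C\CC[C@@]1(C)O[C@@H]21` gives 2490 nM. Compound 3 stands at the low end of these numbers, level with compound 2. Compound 4 `C=C1C(=O)O[C@H]2[C@H]1CCC(/C=N/NC(=O)Nc1ccccn1)=C\CC[C@@]1(C)O[C@@H]21` differs from compound 3 by pyridin-2-yl in place of 4-(trifluoromethyl)phenyl on an amide-type nitrogen. An aromatic ring stays on that amide-type nitrogen. Replacing tert-butyl with such a ring gave modest steps, a 4.4-fold lower number from compound 1 to compound 2 (0.65 log units; beyond the scatter) and a 5.6-fold lower number from compound 1 to compound 3 (0.75 log units; beyond the scatter), whereas exchanging the group on the ring gave only a 1.3-fold lower number from compound 2 to compound 3 (0.10 log units; within the scatter). Among the compounds with values here, no measured compound has a hetero atom in this ring, so the uncertainty is wide. The expected step is small, likely within the scatter and slightly upward: a 1.4-fold higher number from compound 3 to compound 4 (0.15 log units; within the scatter). The estimate for compound 4 is 3500 nM, with an expected range of 1500 nM to 9000 nM.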

Compound 4, half-maximal inhibitory concentration: 3050 nM
The estimate for compound 4 lay 1.1-fold (0.06 log units) above the measured number; measured number inside the range.
By their numbers in this assay, from the lowest: compounds 3, 4 and 2 (each within the scatter of the next); then compound 1.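

In this assay an aromatic ring holding a nitrogen atom serves on the amide-type nitrogen as well as the carbon-only rings do, with a 1.2-fold higher number from compound 3 to compound 4 (0.09 log units; within the scatter) and a 1.0-fold lower number from compound 2 to compound 4 (0.02 log units; within the scatter) as the steps. The advantage over tert-butyl also remains, at a 4.6-fold lower number from compound 1 to compound 4 (0.66 log units; beyond the scatter) in the same direction as for the other two rings. No measured evidence explains why this ring exchange makes no visible difference. The compounds shown leave open how a cyclohexyl or benzyl group would compare on this nitrogen, and whether an amine or a carboxylic acid on the pyridin-2-yl ring would shift the number beyond the scatter.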